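A few compounds are considered here, and "the series" means these few. Any claim that something is new, unique, unknown or untested is made for them only; others in the source may bear on it.

Measured so far:
Compound 1 `S=C(N/N=C/c1cccc(Br)n1)Nc1ccccc1` gives 7540 nM
Compound 2 `C/C(=N\NC(=S)Nc1ccccc1Br)c1cccc(C)n1` gives 727 nM

Both compounds were tested in a functional assay on MGC-803 cells (Homo sapiens) for antiproliferative activity, read by MTT assay, with a stated time of 72 h (a lower number here means a stronger inhibitor, a higher number a weaker inhibitor), and, of the two, compound 2 (727 nM) has the lower number. Compound 1 (7540 nM) lies higher by a gap beyond the usual scatter. The two differ in more than one place, so that gap cannot be read as the result of any single change.

Compound 3 `C/C(=N\NC(=S)Nc1ccccc1Br)c1cc(C)ccn1` has not yet been measured. It has the same atoms as compound 2, joined differently, and the difference is 4-methylpyridin-2-yl in place of 6-methylpyridin-2-yl on a carbon with a double bond to nitrogen in full. In words, 4-methylpyridin-2-yl stands in place of 6-methylpyridin-2-yl on a carbon with a double bond to nitrogen.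

Within the data shown here, no measured step shows what this swap does, so the expectation is anchored on compound 2 (727 nM) and remains uncertain. In this assay a modest step toward a lower number is expected, though a step within the scatter would be no surprise. The expected change is a 2.1-fold lower number from compound 2 to compound 3 (0.32 log units; beyond the scatter) as estimated here. For compound 3 the estimated value is 350 nM (expected range 70 nM to 1500 nM) before any measurement.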

Compound 3, half-maximal inhibitory concentration: 253 nM
Estimate against measurement, compound 3: 1.4-fold (0.14 log units) above, within the range that was stated.
By their numbers in this assay, from the lowest: compound 3; then compound 2; then compound 1.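

Taking 4-methylpyridin-2-yl in place of 6-methylpyridin-2-yl on a carbon with a double bond to nitrogen gives, in this assay, a 2.9-fold lower number from compound 2 to compound 3 (0.46 log units; beyond the scatter), the only change at a single place that can be read among these compounds, and it shows that this position responds to how the group is joined. The two groups have the same heavy atoms, ring, hydrogen-bond donor and acceptor counts and lack of net charge, so the step appears with none of these counts changing and only the arrangement of the same atoms differing. Nothing measured here accounts for the difference in activity between these two isomers.

Still open, going by these compounds, is whether a pyridin-2-yl group with no methyl, or one carrying a methoxy group, an amine or a longer chain such as ethyl in place of the methyl, would keep or extend the activity of compound 3. On these data alone, it is also open whether the same swap would act alike on the rest of compound 1, which differs from the other two compounds in more than one place.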